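Cytotoxicity notes on the sulfonamide series: compound 1 to compound 3

The compounds below may be only part of what the source reports. "The series", "measured", "known", "first", "only" and "open" are said of these compounds alone.

- compound 1 `Cc1cccc(/C=C2\SC(=S)N(NS(=O)(=O)c3ccccc3)C2=O)c1`: > 50000 nM (limit)
- compound 2 `O=C1/C(=C/c2ccc(Cl)c(Cl)c2)SC(=S)N1NS(=O)(=O)c1cccs1`: > 50000 nM (limit)

In a functional assay on ECV-304 cells (Homo sapiens) for cytotoxicity (on this read-out lower numbers stand for stronger inhibition and higher numbers for weaker inhibition), compound 1 gives > 50000 nM as a limit of the assay and not a number. Compound 3 `O=C1/C(=C/c2ccccc2F)SC(=S)N1NS(=O)(=O)c1ccccc1` differs from compound 1 by 2-fluorophenyl in place of 3-methylphenyl on a double-bonded chain carbon bound to a double-bonded ring carbon with 2-fluorophenyl in place of 3-methylphenyl. Going by the values given here, no measured pair gives a step. The record so far is the limit of > 50000 nM in this assay, at which 2 of the 2 values shown sit, and on that basis no shift beyond the scatter is expected. The expected change is a number no higher from compound 1 to compound 3 (the limit leaves the size open) and it should stay small. For compound 3 the estimate is 50000 nM with an expected range of 20000 nM to 100000 nM and a report as a limit is the likelier outcome.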

Compound 3, half-maximal inhibitory concentration: > 50000 nM
Compound 3: no number, only a limit; the forecaster's own chance of this, stated with the estimate: 80%; the middle value lies on the limit itself.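

No step can be read from compound 1 to compound 3, as both results are limits and not numbers: the limit of > 50000 nM in this assay, at which 3 of the 3 values shown sit.

The compounds shown leave open whether 2-fluorophenyl in place of 3-methylphenyl changes the read-out at all.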